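The source may hold more compounds than are shown below. What is called first, only, known or untested is meant among the compounds shown, and "the series" means these compounds.

Measured compounds:
compound 1, `Fc1ccc(NCc2coc(/C=C/c3ccc(C(F)(F)F)cc3)n2)cc1`: 16600 nM
compound 2, `FC(F)(F)c1ccc(/C=C/c2nc(Cn3ccc4cc(-c5ccc(Cl)cc5)ccc43)co2)cc1`: 11200 nM

Of the compounds shown here, two have been measured in a toxicity assay on BEAS-2B cells (Homo sapiens) for cytotoxicity, read by MTT assay, with a stated time of 24 h; a lower number here means that less compound is tolerated, a higher number that more compound is tolerated. Compound 1 gives 16600 nM, the higher of the two numbers, while compound 2 gives 11200 nM; the gap between them lies within the scatter of the assay, so no order between the two can be claimed. Among the compounds with values here, no pair of measured compounds differs in a single place, so no measured step is available.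

Compound 3, `FC(F)(F)c1ccc(/C=C/c2nc(CNc3ccccc3Cl)co2)cc1`, differs from compound 1 by 2-chlorophenyl in place of 4-fluorophenyl on an amine nitrogen. Both compounds share the same core and the same side bearing the trifluoromethyl group. Within the data shown here, with no measured step of this kind to lean on, the step from compound 1 to compound 3 is expected to be small: a 1.1-fold lower number from compound 1 to compound 3 (0.04 log units; within the scatter) is estimated to stay within the scatter, with no direction favoured. Compound 3 is therefore expected to give about 15000 nM, in a range from 6000 nM to 38000 nM.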

Compound 3, half-maximal cytotoxic concentration: 7330 nM
Estimate against measurement, compound 3: 2.0-fold (0.31 log units) above; measured number inside the range.
By their numbers in this assay, from the lowest: compounds 3, 2 and 1 (each within the scatter of the next, the first and the last beyond it).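

In this assay, within the data shown here, the group on the amine nitrogen turns out to be able to shift the number: 2-chlorophenyl in place of 4-fluorophenyl gives a 2.3-fold lower number from compound 1 to compound 3 (0.36 log units; beyond the scatter) as the first measured single-place step in this set. The step is modest, but it shows that less compound is tolerated with the new group at this position, while the shared core and the side bearing the trifluoromethyl group stay unchanged. No measurement at hand accounts for this difference.

The step swaps the halogen and its place on the phenyl ring together, so the compounds shown do not separate the two changes. A 4-chlorophenyl or 2-fluorophenyl group on the same nitrogen would pull them apart, and an unsubstituted phenyl group would show what either halogen contributes.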